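The compounds below may be only part of what the source reports. "The series", "measured", "known", "first", "only" and "open" are said of these compounds alone.

Four compounds share one core, differing only in the group attached to a saturated chain carbon bound to a carbonyl carbon. Compound 1 `CC(C)[C@H](NC(=O)COc1cccc2ccccc12)C(=O)N[C@@H](CC(=O)O)C(=O)COc1cc(C(F)(F)F)n(C)n1`, compound 2 `CC(C)[C@H](NC(=O)COc1cccc2ccccc12)C(=O)N[C@@H](CC(=O)O)C(=O)CSc1nnnn1-c1ccccc1` and compound 3 `CC(C)[C@H](NC(=O)COc1cccc2ccccc12)C(=O)N[C@@H](CC(=O)O)C(=O)CSc1nnnn1C` have been measured; compound 4 `CC(C)[C@H](NC(=O)COc1cccc2ccccc12)C(=O)N[C@@H](CC(=O)O)C(=O)COc1ccnc(C(F)(F)F)n1` has not. In a functional assay on Jurkat cells (Homo sapiens) for inhibition (on this read-out lower numbers stand for stronger inhibition and higher numbers for weaker inhibition), compound 1 gives 46000 nM, and compound 2 gives 153000 nM. For compound 3 the read-out is only a limit of the assay, > 200000 nM, so compound 3 sits at the weak end of what the method can report, with no exact number.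

Compound 4 arises from compound 3 by (2-(trifluoromethyl)pyrimidin-4-yl)oxy in place of (1-methyl-1H-tetrazol-5-yl)sulfanyl on a saturated chain carbon bound to a carbonyl carbon. The closest comparison is compound 1, which also carries a trifluoromethyl-bearing aromatic ether: the step of an at least 4.3-fold higher number from compound 1 to compound 3 (0.63 log units; beyond the scatter) went to a weaker result, and a 3.3-fold higher number from compound 1 to compound 2 (0.52 log units; beyond the scatter) points the same way for the other sulfanyl tetrazole. Reversing that pattern, the step from compound 3 to compound 4 is expected to be an at least 3.3-fold lower number from compound 3 to compound 4 (0.52 log units; beyond the scatter). Compound 4 is therefore estimated at 60000 nM, within a range from 20000 nM to 200000 nM.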

Compound 4, half-maximal inhibitory concentration: 37000 nM
Compound 4: the middle estimate sits 1.6-fold (0.21 log units) above what was measured, within the range that was stated.
By their numbers in this assay, from the lowest: compounds 4 and 1 (each within the scatter of the next); then compound 2. At a limit, above all of these: compound 3.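

Compound 4 shows that a second trifluoromethyl-bearing aromatic ether at this position also separates clearly from the tetrazole sulfanyl groups, with a 4.1-fold lower number from compound 2 to compound 4 (0.62 log units; beyond the scatter) and an at least 5.4-fold lower number from compound 3 to compound 4 (0.73 log units; beyond the scatter). The second of these steps is only a floor, as compound 3 has no exact number and stands at a limit of the assay: the limit of > 200000 nM in this assay, at which 1 of the 4 values shown sits. Exchanging the 1-methyl-5-(trifluoromethyl)-1H-pyrazol-3-yl group on the oxygen for 2-(trifluoromethyl)pyrimidin-4-yl leaves the two ethers indistinguishable, with a 1.2-fold lower number from compound 1 to compound 4 (0.09 log units; within the scatter).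

On these data alone, each ether differs from each sulfanyl group in both the linking atom and the ring, so the contribution of oxygen versus sulfur remains open; a (1-methyl-1H-tetrazol-5-yl)oxy group would separate the two. As far as these compounds go, what the trifluoromethyl group itself contributes is also open, and a plain phenoxy group would begin to address that.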